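The source may hold more compounds than are shown below. What is called first, only, known or untested is meant among the compounds shown, and "the series" means these compounds.

Measured in a functional assay on HL-60 cells (Homo sapiens) for cytotoxicity, read by XTT assay, with a stated time of 72 h; a lower number here means a stronger inhibitor, a higher number a weaker inhibitor:
- Compound 1 `CCCCCCCCCCCCCCCCCCc1c(O)cc(O)c(C(C)=O)c1O`: 31000 nM
- Compound 2 `CC(=O)c1c(O)cc(O)cc1OCC=C(C)C`: > 100000 nM (a limit)
- Compound 3 `CCCCCCCCCCCCCCCCCCOc1cc(O)c(C(C)=O)c(O)c1`: > 100000 nM (a limit)

Of these three, only compound 1 has a true number, since the entries for compound 2 and compound 3 are limits of the assay. Compound 4 `CCCCCCCC/C=C\CCCCCCCCc1c(O)cc(O)c(C(C)=O)c1O` keeps the core of compound 1 and differs only in its chain: dec-1-en-1-yl in place of decyl on a saturated chain carbon, eight bonds along the chain from an aromatic carbon. It carries dec-1-en-1-yl in place of decyl. Among the measured compounds shown here, no measured pair shows what such a change does, so no step beyond the scatter is expected in this assay, and no direction is favoured with confidence. The estimate therefore rests on compound 1 at 31000 nM. The expected step is a 1.2-fold lower number from compound 1 to compound 4 (0.09 log units; within the scatter). For compound 4 the estimated value is 25000 nM, with an expected range of 8000 nM to 80000 nM.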

Compound 4, half-maximal inhibitory concentration: > 100000 nM
Compound 4: no number, only a limit; the forecaster's own chance of this, stated with the estimate: 12%; middle value at least 4.0-fold (0.60 log units) away from the limit.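

In this assay, the chain of compound 1 proves sensitive to a single change: dec-1-en-1-yl in place of decyl, on a saturated chain carbon, eight bonds along the chain from an aromatic carbon, gives an at least 3.2-fold higher number from compound 1 to compound 4 (0.50 log units; beyond the scatter). The value for compound 4 is a limit, not a number, so the step has a floor but no known size. Compound 1 remains the only compound here with a true number: the limit of > 100000 nM in this assay, at which 3 of the 4 values shown sit.

From the compounds shown here alone, how far compound 4 lies past its limit stays open. Also open, going by these compounds, is whether a longer chain, or a chain ending in a carboxylic acid, would fare differently at this place.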